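Aryl change from compound 3 to compound 4

The source may hold more compounds than are shown below. What is called first, only, known or untested is meant among the compounds shown, and "the series" means these compounds.

Measured in a functional assay on HeLa cells (Homo sapiens) for inhibition, read by CCK-8 assay, with a stated time of 48 h; on this read-out higher numbers stand for weaker inhibition and lower numbers for stronger inhibition:
compound 1 `COc1cc(-c2ccnc3cc(-c4ccc(Cl)cc4)nn23)cc(OC)c1OC`: 1490 nM
compound 2 `COc1cc(-c2ccnc3cc(-c4ccc(C)c(C)c4)nn23)cc(OC)c1OC`: 241 nM
compound 3 `COc1cc(-c2ccnc3cc(-c4cccc(C)c4)nn23)cc(OC)c1OC`: 4230 nM

Compound 3 stands highest of the three numbers. Compound 4 `COc1ccc(-c2cc3nccc(-c4cc(OC)c(OC)c(OC)c4)n3n2)cc1F` differs from it by 3-fluoro-4-methoxyphenyl in place of 3-methylphenyl on an aromatic carbon. Among the measured compounds shown here, three measured steps bear on this change: a 6.2-fold lower number from compound 1 to compound 2 (0.79 log units; beyond the scatter) and a 2.8-fold higher number from compound 1 to compound 3 (0.45 log units; beyond the scatter) and an 18-fold higher number from compound 2 to compound 3 (1.24 log units; beyond the scatter). For the measured compounds named here, the 3-fluoro-4-methoxyphenyl group resembles the 3,4-dimethylphenyl of compound 2 more closely than the 3-methylphenyl of compound 3, but no fluoro or methoxy analogue has been measured. A modest step to a lower number is therefore expected in this assay. The expected step is a 5.3-fold lower number from compound 3 to compound 4 (0.72 log units; beyond the scatter). For compound 4 the estimate is 800 nM, with an expected range from 200 nM to 3000 nM.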

Compound 4, half-maximal inhibitory concentration: 236 nM
The estimate for compound 4 lay 3.4-fold (0.53 log units) above the measured number; the measured number falls inside the stated range.
By their numbers in this assay, from the lowest: compounds 4 and 2 (each within the scatter of the next); then compound 1; then compound 3.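

In this assay this position takes a 3-fluoro-4-methoxyphenyl group well: an 18-fold lower number from compound 3 to compound 4 (1.25 log units; beyond the scatter), and a 6.3-fold lower number from compound 1 to compound 4 (0.80 log units; beyond the scatter). Against 3,4-dimethylphenyl the change gives a 1.0-fold lower number from compound 2 to compound 4 (0.01 log units; within the scatter), so a second, differently substituted aryl group now stands level with compound 2, which earlier stood alone. No data here account for these steps.

Open, on these data alone, is whether the fluoro or the methoxy group carries the step, and whether 4-methoxyphenyl or 3-fluorophenyl alone would match compound 4. Also open, as far as these compounds go, is how an amine or a carboxylic acid on this aryl ring would read.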